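A few compounds are considered here, and "the series" means these few. Any claim that something is new, unique, unknown or untested is made for them only; others in the source may bear on it.

Working notes on the series. Of the compounds shown here, three share one core and have been measured: compound 1 `CCCOC(=O)C1=C(C)NC(=O)NC1c1ccoc1`, compound 2 `COC(=O)C1=C(C)NC(=O)NC1c1cccs1` and compound 3 `CCCOC(=O)C1=C(C)NC(=O)NC1c1cccs1`. In an assay on membranes from CHO cells for displacement of a labelled ligand from adenosine receptor A1 (Homo sapiens), read by scintillation counting, with a stated time of 60 min, tested at 1 uM (on this read-out higher numbers stand for more inhibition at the one concentration tested (going by the name of the read-out) and lower numbers for less inhibition), compound 1 gives 50%, compound 2 gives 6% and compound 3 gives 43%. On these numbers compound 3 stands second of the three, with compound 1 nearest and compound 2 furthest. Exchanging the five-membered aromatic group on the saturated ring carbon gives a number 7 percentage points lower from compound 1 to compound 3 (within the scatter), so the two are not told apart. Putting ethyl in place of hydrogen on the chain carbon bound to the ester oxygen gives a number 37 percentage points higher from compound 2 to compound 3 (beyond the scatter), the one clear movement in the set.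

Compound 4 `CC1=C(C(=O)OCC(C)C)C(c2cccs2)NC(=O)N1` has not yet been measured in this assay. Against compound 3 the change is methyl in place of hydrogen on a saturated chain carbon bound to two saturated chain carbons, read one bond further out as propyl to isobutyl. Only the ester-chain step bears on it, and there a larger addition produced a number 37 percentage points higher from compound 2 to compound 3 (beyond the scatter). A single further carbon on an already extended chain is expected to move the number little, if at all, and the step from compound 3 to compound 4 is therefore estimated at a number 7 percentage points higher from compound 3 to compound 4 (within the scatter). Compound 4 is expected to give about 50%, within a range of 30% to 70%.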

Compound 4, a percentage reported as inhibition, at one concentration (the size of the read-out at that concentration, not a potency): 25%
Compound 4: middle estimate off by 25 percentage points, on the high side; measured number outside the range, below it.
By their numbers in this assay, from the lowest: compound 2; then compound 4; then compounds 3 and 1 (each within the scatter of the next).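

Within this assay, methyl in place of hydrogen on a saturated chain carbon bound to two saturated chain carbons, read also as propyl to isobutyl, gives a number 18 percentage points lower from compound 3 to compound 4 (beyond the scatter) and so shows that this place responds to a single added methyl, and that the response here is a fall, where the earlier chain step showed only a rise. Taken over the whole change of chain, the data still give a number 19 percentage points higher from compound 2 to compound 4 (beyond the scatter), so part of the rise remains, but among compounds 2, 3 and 4 the number does not climb with the size of the added group, and compound 4 goes against any such trend. Nothing at hand accounts for the fall.

The compounds shown leave open whether a longer unbranched chain such as butyl would keep the number of compound 3 or lose it as isobutyl does, and how a benzyl group would behave at the same place. They also leave open whether propyl to isobutyl has the same effect with furan-3-yl in place of thiophen-2-yl.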